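The source may hold more compounds than are shown below. What is called first, only, known or untested is meant among the compounds shown, and "the series" means these compounds.

Measured compounds of the series:
- compound 1 `CC(C)c1cccc(C(C)C)c1NC(=O)NC(=O)N(c1ccccc1)c1ccccc1` in an assay on microsomes from intestine for inhibition of acyl-CoA:cholesterol acyltransferase (Oryctolagus cuniculus); a lower number here means a stronger inhibitor, a higher number a weaker inhibitor: compound 1 gives 340 nM
- compound 2 `CCN(CC)C(=O)NC(=O)Nc1c(C(C)C)cccc1C(C)C` in this assay: compound 2 gives > 5000 nM
- compound 3 `CC(C)c1cccc(C(C)C)c1NC(=O)NC(=O)OC(c1ccccc1)c1ccccc1` in this assay: compound 3 gives 7800 nM

Compound 2 stands at the edge of what this assay reports: its value is a limit of the assay and not a number, as the limit of > 5000 nM in this assay, at which 1 of the 3 values shown sits, notes. Compound 1 and compound 3 give numbers, and of the two the value of compound 1 is the lower one; neither is linked to compound 2 by a single structural change, so their values are taken only as they stand.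

Compound 4 `CCCCCC(C)OC(=O)NC(=O)Nc1c(C(C)C)cccc1C(C)C` is not yet measured. It differs from compound 2 by (1-methylhexyl)oxy in place of diethylamino on a carbonyl carbon. Compound 4 thus carries an alkoxy group on the carbonyl in place of the dialkylamino group of compound 2, while the rest of the shared core is unchanged. For the measured compounds named here, no measured pair shows this change, so the size of the step is open. Because compound 2 gives only > 5000 nM, a step in this assay can only be read if compound 4 returns a number. Compound 4 is expected at about 3000 nM, in a range of 700 nM to 15000 nM, which would mean an estimated step of an at least 1.6-fold lower number from compound 2 to compound 4 (0.22 log units; that floor lies within the scatter).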

Compound 4, half-maximal inhibitory concentration: 1060 nM
Compound 4: the middle estimate sits 2.8-fold (0.45 log units) above what was measured; the measured number falls inside the stated range.
By their numbers in this assay, from the lowest: compound 1; then compound 4; then compound 3.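

In this assay, placing (1-methylhexyl)oxy instead of diethylamino on the carbonyl carbon gives an at least 4.7-fold lower number from compound 2 to compound 4 (0.67 log units; beyond the scatter), so this position admits a change that moves the result clear of the scatter. Only a floor can be given for the size of this step, since compound 2 is a limit and not a number: the limit of > 5000 nM in this assay, at which 1 of the 4 values shown sits. Compound 4 also shows that a group with no ring at this place can return a number in this assay, at 1060 nM, which compound 1 and compound 3, both carrying phenyl rings, could not show.

The step changes two things at once, the atom bound to the carbonyl carbon and the size of the chain, and the compounds shown do not separate the two. From the compounds shown here alone, still open in this assay is how a (1-methylhexyl)amino group on the same carbonyl carbon would compare with compound 4, and how a shorter ethoxy group or a longer unbranched octyloxy chain would read there.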